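Dropping the cyano group: from compound 2 to compound 4

The compounds below may be only part of what the source reports. "The series", "measured", "known", "first", "only" and "open" are said of these compounds alone.

Three compounds have been measured in a physicochemical assay for lipophilicity, read by HPLC, at pH 7.4; on this read-out higher numbers stand for higher lipophilicity and lower numbers for lower lipophilicity:

Compound 1, `CNc1nc(NCCCN(C)C)c2sc(-c3ccc(N)cc3)cc2n1`: 2.3
Compound 2, `CNc1nc(NCCCN(C)C)c2sc(-c3cccc(C#N)c3)cc2n1`: 2.9
Compound 3, `CNc1nc(NCCCN(C)C)c2sc(-c3ccc(C(C)=O)cc3)cc2n1`: 2.9

Compound 2 stands level with compound 3 in this assay, with no change at the digits printed from compound 2 to compound 3 (within the scatter), and the two together give the highest of the three numbers; compound 1 lies lowest, a number 0.60 log units higher from compound 1 to compound 2 (beyond the scatter). Compound 4, `CNc1nc(NCCCN(C)C)c2sc(-c3ccccc3)cc2n1`, has not yet been measured. Its difference from compound 2 is hydrogen in place of cyano on an aromatic carbon. Within the data shown here, none of the measured steps removes a group outright in this way: the step of a number 0.60 log units higher from compound 1 to compound 3 (beyond the scatter) and the step of a number 0.60 log units higher from compound 1 to compound 2 (beyond the scatter) both swap one substituent for another, and the step of no change at the digits printed from compound 2 to compound 3 (within the scatter) moves between two substituted rings without a shift beyond the scatter. The data therefore give no direct guide, and only a modest expectation can be drawn. For compound 4 the expected result in this assay is 3.2, within a range of 2.8 to 3.6, which would mean an expected step of a number 0.30 log units higher from compound 2 to compound 4 (within the scatter).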

Compound 4, distribution coefficient: 2.2
For compound 4 the middle estimate is 1.00 log units above the measured one, and the stated range ends above it.
By their numbers in this assay, from the lowest: compounds 4 and 1 (each within the scatter of the next); then compounds 2 and 3 (each within the scatter of the next).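

In this assay, the phenyl ring of compound 4 gives the first comparison against hydrogen: the change from 3-cyanophenyl to phenyl gives a number 0.70 log units lower from compound 2 to compound 4 (beyond the scatter) and the change from acetyl to hydrogen gives a number 0.70 log units lower from compound 3 to compound 4 (beyond the scatter) on the same shared core. Amino does not separate from hydrogen in this way, with a number 0.10 log units lower from compound 1 to compound 4 (within the scatter) within the scatter, so the earlier gap between compound 1 and the other two now reads as a rise with cyano or acetyl and not as a drop with amino. Nothing available explains why these groups differ.

On these data alone, it remains open whether a carboxylic acid, a methoxy group or a chlorine atom on this ring would group with cyano and acetyl or with amino and hydrogen. As far as these compounds go, whether these steps hold with a longer chain on the shared core is also open.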